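Extending the methoxy of compound 3 toward a pyridine ether

A few compounds are considered here, and "the series" means these few. Any claim that something is new, unique, unknown or untested is made for them only; others in the source may bear on it.

Measured compounds:
compound 1, `CCCCNc1nc(N)nc2ccc(CO)cc12`: 0.2 uM
compound 2, `CCCCNc1nc(N)nc2cc(F)c(F)cc12`: 0.1 uM
compound 3, `CCCCNc1nc(N)nc2cccc(OC)c12`: 0.1 uM

All three share one core and the same butylamino and amino groups; they differ only in what sits on the benzo part of the core. In an ADME assay on HEK293 cells for agonist activity at Toll-like receptor 8 (Homo sapiens), read by a luciferase reporter, with a stated time of 6 h (on this read-out higher numbers stand for an effect only at larger amounts of compound and lower numbers for an effect already at smaller amounts), compound 3 gives 0.1 uM. In this assay compound 2 gives 0.1 uM, the same number as compound 3. In this assay compound 1 gives 0.2 uM, and the gap between compound 1 and compound 3 stays within the usual scatter, so the three measured compounds cannot be ranked against one another on these numbers.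

Compound 4, `CCCCNc1nc(N)nc2cccc(OCc3ccccn3)c12`, has not been measured. It differs from compound 3 by one change: pyridin-2-yl in place of hydrogen on a saturated chain carbon bound to an oxygen on an aromatic ring. Going by the values given here, no two measured compounds differ by exactly this change, so nothing measured shows its size directly. Because compound 3 gives 0.1 uM and the group that enters is added onto the methoxy rather than replacing it, the expected step from compound 3 to compound 4 is no change at the digits printed from compound 3 to compound 4 (within the scatter), that is, no change beyond the scatter. In this assay compound 4 is thus estimated at 0.1 uM, with a likely range from 0.03 uM to 0.5 uM.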

Compound 4, minimum effective concentration: 18.5 uM
Compound 4: the middle estimate sits 190-fold (2.27 log units) below what was measured; the whole stated range lies below it.
By their numbers in this assay, from the lowest: compounds 2, 3 and 1 (each within the scatter of the next); then compound 4.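

In this assay, adding pyridin-2-yl to the saturated chain carbon of the methoxy group gives a 190-fold higher number from compound 3 to compound 4 (2.27 log units; beyond the scatter). Going by these compounds alone, this is the first step that lies beyond the usual scatter, so the group on this oxygen is not free to grow without consequence: turning methoxy into (pyridin-2-yl)methoxy means that far more compound is needed before an effect appears. Nothing available here explains why the number rises so sharply.

The compounds shown leave open whether the pyridine nitrogen, the aromatic ring or simply the greater length of the group accounts for the step, and a phenyl ring in place of the pyridine, or a short chain such as ethoxy or propoxy in place of the methoxy, would begin to separate these possibilities. Going by these compounds, it also remains open whether the same pyridin-2-yl extension would have a similar effect elsewhere on the benzo part of the shared core, for example on the hydroxymethyl group of compound 1.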